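The source may report more compounds than this note shows. Statements on the series, on what has been measured and on what is new or still open speak of the compounds shown alone.

Measured compounds:
compound 1 `COc1ccc(NC2=CC(=O)c3c(nc4n3[C@H]3OC[C@@H](O)[C@H]3OC4)C2=O)cc1` — 4470 nM
compound 2 `O=C1C=C(N2CCCCC2)C(=O)c2c1nc1n2[C@H]2OC[C@@H](O)[C@H]2OC1` — > 8000 nM

Working notes. Among the measured compounds shown here, in a functional assay on MCF7 cells (Homo sapiens) for inhibition, read by sulforhodamine B assay (a higher number here means a weaker inhibitor, a lower number a stronger inhibitor), compound 1 gives 4470 nM, which is the only number in the set; it therefore stands as the sole fixed point. In this assay compound 2 gives > 8000 nM, a limit of the assay and not a number, as recorded in the limit of > 8000 nM in this assay, at which 1 of the 2 values shown sits. For the measured compounds named here, no pair of measured compounds differs in one place, so no measured step is available, and the pair of compound 1 and compound 2 shows only that one lies at a number and the other at the limit.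

Compound 3 `O=C1C(N2CCC2)=CC(=O)c2c1nc1n2[C@H]2OC[C@@H](O)[C@H]2OC1` is not yet measured in this assay. It differs from compound 1 by azetidin-1-yl in place of (4-methoxyphenyl)amino on a double-bonded ring carbon. The replacement sets a small cyclic amine on the double-bonded ring carbon, as compound 2 also carries a cyclic amine there, though the two are not a single-change pair and nothing further can be read from them. In this assay the step of a 2.0-fold higher number from compound 1 to compound 3 (0.30 log units; within the scatter) is expected to run toward weaker inhibition, well beyond the scatter, since compound 2 with a cyclic amine at that carbon sits at > 8000 nM. Compound 3 is expected near 9000 nM, within 3000 nM to 25000 nM, with a real chance that only a limit is returned.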

Compound 3, half-maximal inhibitory concentration: > 16000 nM
Compound 3: a limit, no number (the forecaster's own chance of this, stated with the estimate: 55%); middle value at least 1.7-fold (0.24 log units) from the limit.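

In this assay, this double-bonded ring carbon now has its first single-change step: azetidin-1-yl in place of (4-methoxyphenyl)amino gives an at least 3.5-fold higher number from compound 1 to compound 3 (0.55 log units; beyond the scatter), a loss of inhibition beyond the scatter. The earlier compounds shown here offered no such step, and this one shows that the shared core does not keep its measurable inhibition when (4-methoxyphenyl)amino is exchanged for this small cyclic amine. As far as these compounds go, compound 3 gives > 16000 nM, which is a limit of the assay and not a number, so the step fixes only a minimum size and its full size stays unknown because of that limit: the limit of > 16000 nM in this assay, at which 1 of the 3 values shown sits.

The change removes a six-membered aromatic ring of carbon only and a hydrogen-bond donor together, so the compounds shown cannot say which of these departures, or the change in group size, accounts for the loss. A plain phenylamino group would test the role of the methoxy group, and a cyclopropylamino group would keep a small ring together with a nitrogen-bound hydrogen, but neither lies among the compounds shown here.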